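Cytotoxicity ceiling held across three analogues; a sulfonamide tested next

The compounds below may be only part of what the source reports. "The series", "measured", "known", "first", "only" and "open" are said of these compounds alone.

Three compounds share one core and differ only in the aryl group on the amide-type nitrogen in the ring. In a functional assay on HEK293 cells (Homo sapiens) for cytotoxicity (a higher number here means that more compound is tolerated, a lower number that less compound is tolerated), compound 1 `COc1ccc([C@H]2CC(=O)N(c3ccc(C)c(N)c3)C2)cc1OC1CCCC1` gives > 10000 nM, which is a limit of the assay rather than a number. Compound 2 `COc1ccc([C@H]2CC(=O)N(c3ccc(C#N)cc3)C2)cc1OC1CCCC1` gives > 10000 nM in this assay, again a limit. Compound 3 `COc1ccc([C@H]2CC(=O)N(c3cccc(C)c3)C2)cc1OC1CCCC1` stands at > 10000 nM in this assay, also a limit. Because of the limit of > 10000 nM in this assay, at which 3 of the 3 values shown sit, the steps between them cannot be sized: a step that the two limits leave unreadable from compound 1 to compound 2, a step that the two limits leave unreadable from compound 1 to compound 3 and a step that the two limits leave unreadable from compound 2 to compound 3 all remain unreadable.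

Compound 4 `COc1ccc([C@H]2CC(=O)N(c3cccc(NS(=O)(=O)c4cccc(F)c4)c3)C2)cc1OC1CCCC1` arises from compound 3 by the change (((3-fluorophenyl)sulfonyl)amino in place of methyl on an aromatic carbon). Within the data shown here, none of the measured steps can guide this move, since each sits between two limits. The only evidence is that every aryl variation shown so far stayed at the ceiling. The step of a number no higher from compound 3 to compound 4 (the limit leaves the size open) is therefore expected to stay within the scatter, most likely as another limit. Compound 4 is estimated at 10000 nM, in a range from 4000 nM to 30000 nM.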

Compound 4, half-maximal cytotoxic concentration: > 10000 nM
Compound 4 ended at the assay's limit; the forecaster's own chance of this, stated with the estimate: 65%; the middle value sits exactly at the limit.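

Among these compounds, no step can be sized between compound 3 and compound 4, or between any other compounds here, because all of them sit at the same ceiling: the limit of > 10000 nM in this assay, at which 4 of the 4 values shown sit. The compounds shown leave open at what concentration any of them would harm these cells, and whether the aryl groups differ at all in this assay once that ceiling is passed.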